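The source may report more compounds than this note shows. Statements on the series, on what has been measured and on what is new or still open speak of the compounds shown alone.

Measured compounds:
Compound 1, `Cc1cc(Cc2ccc(C(F)(F)F)cc2)c(=O)n(CC(=O)Nc2ccc(Br)cc2)n1`: in an assay on HL-60 cells for agonist activity at N-formyl peptide receptor 3 (Homo sapiens), read by calcium flux (on this read-out higher numbers stand for an effect only at larger amounts of compound and lower numbers for an effect already at smaller amounts), compound 1 gives > 50000 nM, which is a limit of the assay and not a number.
Compound 2, `Cc1cc(Cc2ccoc2)c(=O)n(CC(=O)Nc2ccc(Br)cc2)n1`: in this assay compound 2 gives > 50000 nM, again a limit of the assay.
Compound 3, `Cc1cc(Cc2ccc(C(N)=O)cc2)c(=O)n(CC(=O)Nc2ccc(Br)cc2)n1`: in this assay compound 3 gives > 50000 nM, also a limit of the assay.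

Compound 2 therefore stands where every other measured compound stands: at the limit of > 50000 nM in this assay, at which 3 of the 3 values shown sit. No ordering among the three can be read, since none of them gave a number.

Compound 4, `Cc1cc(N)c(=O)n(CC(=O)Nc2ccc(Br)cc2)n1`, keeps the shared core of compound 2 and the bromophenyl amide chain, but differs at one place: amino in place of (furan-3-yl)methyl on an aromatic carbon. The measured steps that touch this part of the molecule are a step that the two limits leave unreadable from compound 1 to compound 2 and a step that the two limits leave unreadable from compound 2 to compound 3, and the further step that the two limits leave unreadable from compound 1 to compound 3; all three are unreadable in size, as each connects two limits. They give no direction and no size for the change to compound 4, which removes the whole (furan-3-yl)methyl group rather than swapping one ring for another.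

With nothing beyond limits to build on, compound 4 is expected to behave like its neighbours, so the expected step that the limit leaves unreadable from compound 2 to compound 4 is none beyond the scatter. Compound 4 is estimated at 60000 nM in this assay, within 15000 nM to 300000 nM, most probably reported again only as a limit.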

Compound 4, half-maximal effective concentration: > 50000 nM
Compound 4: no number, only a limit (the forecaster's own chance of this, stated with the estimate: 85%); the middle value does not contradict the limit.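

Compound 2 and compound 4 both give only a limit of the assay and not a number, so no step between them can be read, and the same holds for every other pair here: the limit of > 50000 nM in this assay, at which 4 of the 4 values shown sit.

The compounds shown leave open whether any group at this place gives a true number in this assay, and how far these compounds differ from one another.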